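A few compounds are considered here, and "the series" means these few. Any claim that something is new, unique, unknown or untested is made for them only; others in the source may bear on it.

Compound 1 `CN1C[C@H](C(=O)Nc2ccc(F)c(F)c2)[C@@H](c2ccc(/C=C/C(=O)Nc3ccccc3N)cc2)C1`: 46 mL/min/kg
Compound 2 `Cc1cc(NC(=O)[C@H]2CN(C)C[C@@H]2c2ccc(/C=C/C(=O)Nc3ccccc3N)cc2)ccc1F`: 62 mL/min/kg

In an in vitro ADME assay on microsomes from liver (Mus musculus) for pharmacokinetics, read by LC-MS, with a stated time of 10 min, tested at 1 uM (on this read-out higher numbers stand for fast clearance and lower numbers for slow clearance), compound 2 gives 62 mL/min/kg, which stands within the scatter of compound 1 at 46 mL/min/kg. Compound 3 `CN1C[C@H](C(=O)Nc2ccc(Cl)cc2F)[C@@H](c2ccc(/C=C/C(=O)Nc3ccccc3N)cc2)C1` differs from compound 2 as follows: 4-chloro-2-fluorophenyl in place of 4-fluoro-3-methylphenyl on an amide-type nitrogen. It carries 4-chloro-2-fluorophenyl in place of 4-fluoro-3-methylphenyl on an amide-type nitrogen. Going by the values given here, only one measured step bears on this change, a 1.3-fold higher number from compound 1 to compound 2 (0.13 log units; within the scatter), and it is small. No step beyond the scatter is therefore expected, and the estimated change is a 1.2-fold lower number from compound 2 to compound 3 (0.09 log units; within the scatter). For compound 3 the expected clearance is 50 mL/min/kg, with an estimated range of 27 mL/min/kg to 92 mL/min/kg.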

Compound 3, clearance: 43 mL/min/kg
The estimate for compound 3 lay 1.2-fold (0.07 log units) above the measured number; measured number inside the range.
By their numbers in this assay, from the lowest: compounds 3, 1 and 2 (each within the scatter of the next).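

In this assay the 4-chloro-2-fluorophenyl group on the amide-type nitrogen gives a 1.4-fold lower number from compound 2 to compound 3 (0.16 log units; within the scatter) and a 1.1-fold lower number from compound 1 to compound 3 (0.03 log units; within the scatter) when set against the two earlier aryl groups. The earlier compounds had shown only a swap of methyl and fluoro, whereas this change also brings in chlorine and still separates none of the three compounds in clearance. Nothing available explains these numbers. Going by these compounds, whether a pyridine ring or a saturated amine on this nitrogen would move clearance beyond the scatter remains open.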